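A Small Polar Amide Substituent on a Shared Core

The source may hold more compounds than are shown below. What is called first, only, known or untested is meant among the compounds shown, and "the series" means these compounds.

Three amides share one core. Compound 1 `CCn1c(C(=O)NCC#N)ccc1C(CC)(CC)c1ccc(OCCC(O)(CC)CC)c(C)c1` carries cyanomethyl on the amide nitrogen; in a functional assay on HepG2 cells (Homo sapiens) for antiproliferative activity, read by MTT assay, with a stated time of 48 h (a higher number here means a weaker inhibitor, a lower number a stronger inhibitor), compound 1 gives only a limit, > 50000 nM. Compound 2 `CCOc1ccc(NC(=O)c2ccc(C(CC)(CC)c3ccc(OCCC(O)(CC)CC)c(C)c3)n2CC)cc1` carries 4-ethoxyphenyl there; in this assay compound 2 likewise reaches only a limit, > 50000 nM. Compound 3 `CCOC(=O)C(CC(=O)OC)NC(=O)c1ccc(C(CC)(CC)c2ccc(OCCC(O)(CC)CC)c(C)c2)n1CC` also gives only a limit, > 50000 nM. All three thus sit together at the limit of > 50000 nM in this assay, at which 3 of the 3 values shown sit, so the steps a step that the two limits leave unreadable from compound 1 to compound 2, a step that the two limits leave unreadable from compound 1 to compound 3 and a step that the two limits leave unreadable from compound 2 to compound 3 cannot be sized. Compound 4 `CCn1c(C(=O)NC(C)CO)ccc1C(CC)(CC)c1ccc(OCCC(O)(CC)CC)c(C)c1` differs from compound 2 by 1-(hydroxymethyl)ethyl in place of 4-ethoxyphenyl on an amide-type nitrogen, a change on the same amide-type nitrogen as those unreadable steps. With no readable step to lean on, compound 4 is expected to stay near the limit, a step that the limit leaves unreadable from compound 2 to compound 4. The estimate for compound 4 is 60000 nM, ranging from 20000 nM to 200000 nM.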

Compound 4, half-maximal inhibitory concentration: 43100 nM
The estimate for compound 4 lay 1.4-fold (0.14 log units) above the measured number; the range from low to high includes it.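

Going by these compounds alone, compound 4, with 1-(hydroxymethyl)ethyl on the amide-type nitrogen, is the first of these amides to give a true number in this assay, 43100 nM. The steps to it are an at least 1.1-fold lower number from compound 2 to compound 4 (0.06 log units; that floor lies within the scatter), an at least 1.1-fold lower number from compound 3 to compound 4 (0.06 log units; that floor lies within the scatter) and an at least 1.1-fold lower number from compound 1 to compound 4 (0.06 log units; that floor lies within the scatter). Each is only a floor, so the real size of the change stays unknown, and the other amides remain at the limit: the limit of > 50000 nM in this assay, at which 3 of the 4 values shown sit.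

The compounds shown leave open whether an amine, a carboxylic acid or a longer chain on this nitrogen would give a number clearly beyond the scatter from that limit.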